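Adding a Methyl at a Different Place on the Core

The source may hold more compounds than are shown below. What is called first, only, known or untested is meant among the compounds shown, and "the series" means these compounds.

Of the compounds shown here, three sharing a core have been measured in a functional assay on CAKI-1 cells (Homo sapiens) for antiproliferative activity; on this read-out lower numbers stand for stronger inhibition of growth and higher numbers for weaker inhibition of growth. Compound 1 `Cc1ccnc2nc(-c3cccc(Cl)c3)cc(O)c12` gives 33.1 nM. Compound 3 `Cc1cc(C)c2c(O)cc(-c3cccc(Cl)c3)nc2n1` gives 204 nM. Compound 2 `Oc1cc(-c2ccc3ccccc3c2)nc2ncccc12` gives 5620 nM, the highest of the three numbers. Compound 1 and compound 3 differ in one place, (methyl in place of hydrogen on an aromatic carbon), and this step gives a 6.2-fold higher number from compound 1 to compound 3 (0.79 log units; beyond the scatter). How the core of compound 1 differs from that of compound 2 is not broken down here.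

Compound 4 `Cc1ccnc2nc(-c3ccc4ccccc4c3)cc(O)c12` has not yet been measured. It differs from compound 2 in one place, (methyl in place of hydrogen on an aromatic carbon). This is the same kind of change as from compound 1 to compound 3, but the surroundings differ: there the methyl entered next to the ring nitrogen, meta to a methyl group and para to a fused ring, whereas here it enters ortho to a fused ring, meta to a fused ring and opposite the ring nitrogen.

In this assay compound 4 is expected to give 2500 nM, likely between 600 nM and 10000 nM. The step from compound 2 to compound 4 is expected to be a 2.2-fold lower number from compound 2 to compound 4 (0.35 log units; beyond the scatter). Going by the values given here, this expectation rests on compound 1, which carries a methyl at this place and gives 33.1 nM, while the only measured methyl step, a 6.2-fold higher number from compound 1 to compound 3 (0.79 log units; beyond the scatter), sits at a different place and so offers no direct guide.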

Compound 4, concentration for 50% growth inhibition: 2400 nM
The estimate for compound 4 lay 1.0-fold (0.02 log units) above the measured number, and the stated range covers the measured number.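

In this assay, putting a methyl in place of hydrogen on an aromatic carbon of compound 2 gives a 2.3-fold lower number from compound 2 to compound 4 (0.37 log units; beyond the scatter), a modest step towards stronger inhibition of growth. The earlier methyl step went the other way, so this change brings neither a fixed size nor a fixed direction from one core to the other: the same change on two cores in this assay, a 6.2-fold higher number (0.79 log units; beyond the scatter) from compound 1 to compound 3 and a 2.3-fold lower number (0.37 log units; beyond the scatter) from compound 2 to compound 4, 14-fold (1.16 log units) apart, beyond the scatter of two such steps What this does not show is the reason, since the methyl enters at a different place in each pair and the rest of the molecule differs as well, and two steps cannot separate those influences or make a rule for the whole series.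

The compounds shown leave open how a larger or different group, such as an ethyl, a methoxy group or an amine, would behave at the place opposite the ring nitrogen. They also leave open whether a methyl at that same place would give a similar step on other cores in the series.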